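Aryl and benzylic amine variation at the indole amino position

The compounds below may be only part of what the source reports. "The series", "measured", "known", "first", "only" and "open" are said of these compounds alone.

Measured compounds:
- compound 1, `CCOC(=O)c1c(N2CCCC2)[nH]c2ccc(O)cc12`, "not determined" (no result reported) in an assay on isolated protein for inhibition of Polyunsaturated fatty acid 5-lipoxygenase (Homo sapiens), tested at 10 uM; a higher number here means more inhibition at the concentration tested (going by the name of the read-out), a lower number less inhibition
- compound 2, `CCOC(=O)c1c(Nc2ccc(C)cc2)[nH]c2ccc(O)cc12`, 77%
- compound 3, `CCOC(=O)c1c(NC(C)c2ccccc2)[nH]c2ccc(O)cc12`, 72%

Among the measured compounds shown here, compound 3 holds the lowest of the two numbers in this assay, but the only step that reaches it, a number 5 percentage points lower from compound 2 to compound 3 (within the scatter), lies within the scatter, so compound 2 and compound 3 cannot be told apart on these data. Compound 1 contributes no number.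

Compound 4, `CCOC(=O)c1c(Nc2cccc(Cl)c2)[nH]c2ccc(O)cc12`, differs from compound 3 by 3-chlorophenyl in place of 1-phenylethyl on a nitrogen on an aromatic ring. The change returns to a six-membered aromatic ring on the nitrogen, as in compound 2, but with 3-chlorophenyl rather than 4-methylphenyl. For the measured compounds named here, the only measured step that bears on it is the exchange of 4-methylphenyl for 1-phenylethyl, a number 5 percentage points lower from compound 2 to compound 3 (within the scatter), which was within the scatter. Going by the values given here, no measured pair addresses a chlorine substituent. The expected step of a number 3 percentage points higher from compound 3 to compound 4 (within the scatter) is therefore none beyond the scatter, in either direction.

For compound 4 the estimated value in this assay is 75%, with a range from 60% to 88%.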

Compound 4, a percentage reported as inhibition, at one concentration (the size of the read-out at that concentration, not a potency): 97%
Compound 4: middle estimate off by 22 percentage points, on the low side, outside the stated range (above it).
By their numbers in this assay, from the lowest: compounds 3 and 2 (each within the scatter of the next); then compound 4.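

The nitrogen substituent now separates compounds in this assay where the earlier pair did not: 3-chlorophenyl in place of 1-phenylethyl gives a number 25 percentage points higher from compound 3 to compound 4 (beyond the scatter) and 3-chlorophenyl in place of 4-methylphenyl gives a number 20 percentage points higher from compound 2 to compound 4 (beyond the scatter) on the same shared core. This place therefore responds to the choice of aromatic group, and compound 4 stands apart from both compound 2 and compound 3, which remain within the scatter of each other. Nothing available here bears on why the 3-chlorophenyl group gives this result.

On these data alone, whether the rise belongs to the chlorine itself or to its place on the phenyl ring stays open, and plain phenyl, 4-chlorophenyl and 3-methoxyphenyl groups on this nitrogen would help separate these readings. Also open, as far as these compounds go, is how far the result holds with a carboxylic acid or an amide in place of the ethyl ester.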